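The compounds below may be only part of what the source reports. "The series", "measured", "known", "first", "only" and "open" are said of these compounds alone.

Measured compounds:
- compound 1 `Cc1c(OCCCCOc2ccccc2C(=O)O)ccc(C(=O)CC2CCCC2)c1C`, 2580 nM
- compound 2 `CCCC(=O)c1ccc(OCCCCOc2ccc(F)c(C(=O)O)c2)c(C)c1O`, 74 nM
- compound 3 `CC(=O)c1ccc(OCCCCOc2ccc(C(=O)O)cc2C)c(C)c1O`, 50 nM

In an assay on HEK293 cells for positive allosteric modulation of metabotropic glutamate receptor 2 (Rattus norvegicus), read by thallium flux, with a stated time of 2.5 min (on this read-out higher numbers stand for an effect only at larger amounts of compound and lower numbers for an effect already at smaller amounts), compound 2 gives 74 nM, the second highest of the three numbers. Its nearest neighbour is compound 3 with 50 nM, a gap within the usual scatter, so the two cannot be ordered. The furthest is compound 1 with 2580 nM, a gap well beyond the scatter; compound 1 differs from compound 2 in more than one place, so no single change can be read from that pair.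

Compound 4 `Cc1c(OCCCCOc2ccc(F)c(C(=O)O)c2)ccc(C(=O)CC(C)C)c1O` is not yet measured in this assay. It differs from compound 2 by methyl in place of hydrogen on a saturated chain carbon bound to two saturated chain carbons. Among the measured compounds shown here, no pair of measured compounds shows this change on its own, so there is no measured step to lean on. With only a single carbon added on a saturated chain carbon, the expected step of a 1.2-fold higher number from compound 2 to compound 4 (0.09 log units; within the scatter) is small, in no fixed direction, and not beyond the scatter. Compound 4 is therefore estimated at 90 nM, with a range from 30 nM to 270 nM.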

Compound 4, half-maximal effective concentration: 153 nM
Compound 4: the middle estimate sits 1.7-fold (0.23 log units) below what was measured, within the range that was stated.
By their numbers in this assay, from the lowest: compounds 3 and 2 (each within the scatter of the next); then compound 4; then compound 1.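

In this assay, among the compounds shown here, the change from propylcarbonyl to isobutylcarbonyl gives a 2.1-fold higher number from compound 2 to compound 4 (0.32 log units; beyond the scatter), which is the first step that can be read from a single difference. This position on the saturated chain is therefore not indifferent to methyl in place of hydrogen: the step is modest but lies beyond the scatter, and it runs towards a higher number, though it rests on this one pair alone. Nothing at hand gives a reason for this step.

Going by these compounds, whether the same change would give a similar step on the other compounds remains open, since compound 1 and compound 3 each differ from compound 2 in more than one place and no matched partner of either appears here. Also open, on these data alone, is how the same chain carbon responds to other groups, such as an amine or a hydroxyl in place of the methyl, and whether a longer chain such as pentylcarbonyl would continue the step or reverse it.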